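Working notes: from compound 3 to compound 4

This account rests on a few compounds, and the source may have more. Where it says the series, first, only, none or still open, it means among the compounds named here.

Three amides on a shared core have been measured in a physicochemical assay for solubility, measured as kinetic solubility, with a stated time of 1 h, at pH 7.4; a lower number here means a less soluble compound, a higher number a more soluble compound. Compound 1 `CC(=O)N[C@@H](C)C(=O)NC1=NN(c2ccc(Cl)c(Cl)c2)CC1` gives 58000 nM, and compound 2 `O=C(NC1=NN(c2ccc(Cl)c(Cl)c2)CC1)c1ccccn1` gives 11000 nM. Compound 3 `O=C(NC1=NN(c2ccc(Cl)c(Cl)c2)CC1)c1ccnnc1` gives 23000 nM, the second highest of the three numbers, with compound 2 its nearest neighbour and compound 1 the furthest.

Compound 4 `Cc1ncncc1C(=O)NC1=NN(c2ccc(Cl)c(Cl)c2)CC1` carries 4-methylpyrimidin-5-yl in place of pyridazin-4-yl on a carbonyl carbon.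

Going by the values given here, the closest guide is the only measured swap of one aromatic ring for another, a 2.1-fold higher number from compound 2 to compound 3 (0.32 log units; beyond the scatter), a modest step. The two steps that remove 1-acetamidoethyl are also modest: a 5.3-fold lower number from compound 1 to compound 2 (0.72 log units; beyond the scatter) and a 2.5-fold lower number from compound 1 to compound 3 (0.40 log units; beyond the scatter). They involve a different kind of change and bear on this one only loosely. Among the compounds with values here, no measured compound carries 4-methylpyrimidin-5-yl or any other methyl-bearing ring, so the data give no firm direction.

Within the data shown here, with only that one ring swap to go on, a step no larger than that modest one is expected in this assay. The expected step is a 1.3-fold lower number from compound 3 to compound 4 (0.11 log units; within the scatter), which is estimated to stay within the scatter. Compound 4 is estimated at 18000 nM, with an expected range of 8000 nM to 42000 nM.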

Compound 4, solubility: 12000 nM
The estimate for compound 4 lay 1.5-fold (0.18 log units) above the measured number; the range from low to high includes it.
By their numbers in this assay, from the lowest: compounds 2, 4 and 3 (each within the scatter of the next, the first and the last beyond it); then compound 1.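

In this assay, 4-methylpyrimidin-5-yl on a carbonyl carbon cannot be told apart from pyridazin-4-yl (a 1.9-fold lower number from compound 3 to compound 4 (0.28 log units; within the scatter)) or from pyridin-2-yl (a 1.1-fold higher number from compound 2 to compound 4 (0.04 log units; within the scatter)), even though those two earlier rings differ from each other by a step beyond the scatter. Compound 4 therefore sits within the scatter of both earlier ring amides, so this third ring does not extend the range that they span. The step from 1-acetamidoethyl to this ring (a 4.8-fold lower number from compound 1 to compound 4 (0.68 log units; beyond the scatter)) lies beyond the scatter and points the same way as the steps to compound 2 and compound 3, so all three aromatic rings shown give lower numbers than compound 1, with no compound among them going against this. Nothing at hand gives a reason for these steps.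

The compounds shown do not separate the effect of the methyl group from that of the ring that carries it. From the compounds shown here alone, it also remains open whether a carboxylic acid or a primary amine on the aromatic ring, or a longer chain ending in an amide, would bring the number back towards that of compound 1 (58000 nM).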